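The compounds below may be only part of what the source reports. "The series", "measured", "known", "first", "only" and "open" are said of these compounds alone.

Compound 1 `CC(C)COc1ncc(-c2cn(C)c3cc(C(=O)NS(C)(=O)=O)ccc23)cc1Cl`: 100%
Compound 2 `CC(C)COc1ncc(-c2nn(C)c3cc(C(=O)NS(C)(=O)=O)ccc23)cc1Cl`: 100%

In an ADME assay on microsomes from liver (Mus musculus) for metabolic stability, with a stated time of 10 min, tested at 0.5 uM (a lower number here means that less of the compound is left, a higher number that more of the compound is left), compound 1 stands at 100% and is level with compound 2 within the usual scatter. Compound 3 `CC(C)COc1ncc(-c2cn(C)c3cc(C(=O)NS(C)(=O)=O)c(F)cc23)cc1Cl` departs from compound 1 at one place (fluoro in place of hydrogen on an aromatic carbon): fluoro in place of hydrogen on an aromatic carbon, ortho to a (methylsulfonyl)carbamoyl group. For the measured compounds named here, no measured pair of compounds shows this change, so the expectation rests on the two values alone. No step beyond the scatter is expected, and the estimated change (a number 3 percentage points lower from compound 1 to compound 3 (within the scatter)) stays small. In this assay compound 3 is expected at 97% (estimated range 85% to 100%).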

Compound 3, percent of the compound remaining: 100%
Beside the measured number, compound 3's estimate is 3 percentage points below it; the measured number falls inside the stated range.
By their numbers in this assay, from the lowest: compounds 1, 2 and 3 (each within the scatter of the next).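

In this assay, fluoro in place of hydrogen on an aromatic carbon, ortho to a (methylsulfonyl)carbamoyl group, gives no change at the digits printed from compound 1 to compound 3 (within the scatter). For the compounds shown here, the earlier compounds held no change at this position, so this is the first sign that it accepts fluoro with no step beyond the scatter in this read-out. No supporting evidence bears on this result. Still open, on these data alone, is whether a methoxy group or an amine at the same place would read the same. As far as these compounds go, whether fluoro behaves alike on the core of compound 2 also remains open.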